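The compounds below may be only part of what the source reports. "The series", "measured", "known", "first", "only" and "open" are said of these compounds alone.

Working notes on the series. Compound 3 `O=c1c2ncn(-c3ccccc3)c2nc(N2CCCCC2)n1-c1ccc(Cl)cc1` stands at the limit of a functional assay on HepG2 cells (Homo sapiens) for cytotoxicity, read by MTT assay, with a stated time of 72 h; a higher number here means a weaker inhibitor, a lower number a stronger inhibitor: compound 3 gives > 100000 nM, a limit rather than a number. Two of the three values shown sit at this limit (the limit of > 100000 nM in this assay, at which 2 of the 3 values shown sit). Compound 1 `CN(C)c1nc2c(ncn2-c2ccccc2)c(=O)n1-c1ccccc1` likewise gives > 100000 nM in this assay, again a limit. Compound 2 `CCCCN(CCCC)c1nc2c(ncn2-c2ccccc2)c(=O)n1-c1ccccc1` gives 20400 nM in this assay. Going by the values given here, the only measured step is an at least 4.9-fold lower number from compound 1 to compound 2 (0.69 log units; beyond the scatter). Compound 4 `CNc1nc2c(ncn2-c2ccccc2)c(=O)n1-c1ccc(Cl)cc1` carries methylamino in place of piperidin-1-yl on an aromatic carbon. The measured step ran toward a larger dialkylamino group and gave a lower number; the change to compound 4 runs toward a smaller amino group, the opposite direction, so no drop in the number is expected. Compound 4 is therefore expected to give 100000 nM (range 50000 nM to 300000 nM), most likely once more as a limit. The step of a number no higher from compound 3 to compound 4 (the limit leaves the size open) is expected to be none beyond the scatter.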

Compound 4, half-maximal inhibitory concentration: > 100000 nM
Compound 4 was reported as a limit; the forecaster's own chance of this, stated with the estimate: 85%; the middle value lies on the limit itself.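

Compound 3 and compound 4 both sit at the assay limit, so the step between them cannot be read. The compounds shown leave open how far methylamino and piperidin-1-yl actually differ in this assay.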